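A few compounds are considered here, and "the series" means these few. Any claim that something is new, unique, unknown or untested is made for them only; others in the source may bear on it.

Measured so far:
compound 1 `CCn1c(=O)n(C2OC(CO)[C@@H](O)[C@H]2O)c2nc(N)nc(O)c21`: 82%
compound 2 `C=CCn1c(=O)n(C2C[C@H](O)C(CO)O2)c2nc(N)nc(O)c21`: 99%

Going by the values given here, compound 1 gives the lower of the two values in a functional assay on the whole organism (B cells) with Mus musculus as the target; a lower number here means a smaller maximal response, a higher number a larger maximal response; compound 2 stands a number higher that lies beyond the scatter, and no step is computed between these two, so only their two values are noted. Compound 3 `Nc1nc(O)c2c(n1)n(C1OC(CO)[C@@H](O)[C@H]1O)c(=O)n2CCN1CCCCC1` is not yet measured. It differs from compound 1 as follows: piperidin-1-yl in place of hydrogen on a saturated chain carbon, two bonds along the chain from an aromatic nitrogen. Among the compounds with values here, with no computed step in hand, the expected step of a number 3 percentage points higher from compound 1 to compound 3 (within the scatter) is small, of uncertain direction, and likely within the scatter. Compound 3 is estimated at 85% with a range of 65% to 100%.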

Compound 3, largest response reached (reported as maximal response), in percent of the reference or control that the assay uses: 0%
Compound 3: the middle estimate sits 85 percentage points above what was measured, outside the stated range (below it).
By their numbers in this assay, from the lowest: compound 3; then compound 1; then compound 2.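

In this assay, the change from ethyl to 2-(piperidin-1-yl)ethyl gives a number 82 percentage points lower from compound 1 to compound 3 (beyond the scatter), the first step computed at this position. The maximal response therefore depends strongly on what this chain carries, and a saturated chain carbon two bonds along from an aromatic nitrogen is not a neutral place for substitution in this series. Nothing available explains the loss of response. Going by these compounds, whether it follows from the whole piperidin-1-yl group or only from its ring nitrogen remains open. A dimethylamino group, a morpholin-4-yl group or a plain butyl chain at this place would separate these readings.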